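This account rests on a few compounds, and the source may have more. Where it says the series, first, only, none or still open, it means among the compounds named here.

In a functional assay on DLD-1 cells (Homo sapiens) for cytotoxicity, with a stated time of 48 h (a lower number here means a stronger inhibitor, a higher number a weaker inhibitor), three compounds built on the same core have been measured. Compound 1 `CCCC(=O)Oc1ccc2oc(/C=C/[S+](C)[O-])cc(=O)c2c1` gives 8700 nM, compound 2 `Cc1ccc2oc(/C=C/[S+](C)[O-])cc(=O)c2c1` gives 7000 nM, and compound 3 `CCCOc1ccc2oc(/C=C/[S+](C)[O-])cc(=O)c2c1` gives 6200 nM. Compound 3 thus stands within the scatter of both of the others, and the numbers set no order among the three.

Compound 4 `CC(C)Oc1ccc2oc(/C=C/[S+](C)[O-])cc(=O)c2c1` keeps the core of compound 3 and rearranges only the chain: isopropyl in place of propyl on an oxygen on an aromatic ring. In words, isopropyl stands in place of propyl on an oxygen on an aromatic ring, so the propoxy group becomes isopropoxy.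

Going by the values given here, no measured step tests this exact change. The closest evidence comes from the three steps that swap the group at this place for a different one: a 1.4-fold lower number from compound 1 to compound 3 (0.15 log units; within the scatter), a 1.1-fold lower number from compound 2 to compound 3 (0.05 log units; within the scatter) and a 1.2-fold lower number from compound 1 to compound 2 (0.09 log units; within the scatter). All three stay within the scatter, although each changes the group more than a rearrangement of the same atoms does. No step beyond the scatter is therefore expected in this assay, and the estimated step is a 1.0-fold higher number from compound 3 to compound 4 (0.02 log units; within the scatter). For compound 4 the expected value is 6500 nM, with an estimated range from 3500 nM to 12000 nM.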

Compound 4, half-maximal inhibitory concentration: 8000 nM
Compound 4: the middle estimate sits 1.2-fold (0.09 log units) below what was measured, within the range that was stated.
By their numbers in this assay, from the lowest: compounds 3, 2, 4 and 1 (each within the scatter of the next).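

In this assay, going by these compounds alone, the move from propoxy to isopropoxy is the first change at this place that keeps the same atoms and only joins them differently, and it gives a 1.3-fold higher number from compound 3 to compound 4 (0.11 log units; within the scatter) with the oxygen on the aromatic ring left in place, so branching the chain sets no order between these two compounds. The other new steps (a 1.1-fold higher number from compound 2 to compound 4 (0.06 log units; within the scatter) and a 1.1-fold lower number from compound 1 to compound 4 (0.04 log units; within the scatter)) also stay inside the scatter, which means that isopropoxy joins methyl, propoxy and (propylcarbonyl)oxy in a set of four groups that the numbers do not separate at this aromatic carbon. Nothing in the data shown explains why the change in chain shape leaves the number within the scatter.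

On these data alone, what remains open is whether any group at this place can move the number beyond the scatter, for example a longer chain such as hexyloxy, an amine or a carboxylic acid. It is also open whether the four groups would stay this close together on a changed core, since every compound shown carries the same remainder of the molecule.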